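This account rests on a few compounds, and the source may have more. Where it says the series, first, only, none or still open, it means among the compounds named here.

Compound 1, `Nc1ccccc1-n1ccnc1`: 1300000 nM
Compound 2, `Nc1ccc(Cl)cc1-n1ccnc1`: 88000 nM
Compound 3, `Oc1ccccc1-c1nnn[nH]1`: 700000 nM

Of the compounds shown here, three have been measured in an assay on cells for inhibition of Indoleamine 2,3-dioxygenase 1 (Homo sapiens), read by HPLC, with a stated time of 20 min; on this read-out higher numbers stand for weaker inhibition and lower numbers for stronger inhibition. Compound 1 gives 1300000 nM, and compound 2, which carries a chloro group on the same core, gives 88000 nM. The difference between them is chloro in place of hydrogen on an aromatic carbon, and it produced a 15-fold lower number from compound 1 to compound 2 (1.17 log units; beyond the scatter). Compound 3 rests on a different core, and how the two cores differ is not broken down here; in this assay compound 3 gives 700000 nM, a value that sits within the usual scatter of the value of compound 1, while the value of compound 2 is clearly lower than that of compound 3.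

Compound 4, `Oc1ccc(Cl)cc1-c1nnn[nH]1`, has not yet been measured. It differs from compound 3 by chloro in place of hydrogen on an aromatic carbon. Going by the values given here, this is the same kind of change as the one from compound 1 to compound 2, with one difference in its surroundings: in compound 2 the chloro group sits para to an amino group, whereas in compound 4 it sits para to a hydroxy group. Among the compounds with values here, the expectation for compound 4 rests on the single earlier step, so it carries real uncertainty. Still, because compound 2 showed a 15-fold lower number from compound 1 to compound 2 (1.17 log units; beyond the scatter), a step of similar direction and roughly similar size is expected from compound 3 to compound 4, namely a 12-fold lower number from compound 3 to compound 4 (1.07 log units; beyond the scatter). Compound 4 is therefore estimated to give about 60000 nM in this assay, with a range from 15000 nM to 250000 nM.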

Compound 4, half-maximal inhibitory concentration: 16000 nM
Beside the measured number, compound 4's estimate is 3.8-fold (0.57 log units) above it, within the range that was stated.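

In this assay, chloro in place of hydrogen on an aromatic carbon lowered the number on the second core as well, with a 44-fold lower number from compound 3 to compound 4 (1.64 log units; beyond the scatter), so the direction of the change held from the core of compound 1 to the core of compound 3. The size of the step did not carry over unchanged, and the gap between the two steps is larger than the scatter allows: the same change on two cores in this assay, a 15-fold lower number (1.17 log units; beyond the scatter) from compound 1 to compound 2 and a 44-fold lower number (1.64 log units; beyond the scatter) from compound 3 to compound 4, 3.0-fold (0.47 log units) apart, beyond the scatter of two such steps. This shows that the core has a bearing on how much the chloro group changes the number, but it does not show why the two steps differ, and two pairs of compounds give no basis for predicting the size of the step on a third core.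

The compounds shown leave open whether fluoro, bromo or methyl on the same aromatic carbon would lower the number as chloro does, and whether chloro on another carbon of the ring would have a similar effect. They also leave open how the number would respond if the hydroxy group of compound 4 gave way to a methoxy group or a carboxylic acid while the chloro group stayed in place.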